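Working notes: aryl swap on the aromatic nitrogen

The compounds below may be only part of what the source reports. "The series", "measured", "known", "first", "only" and "open" are said of these compounds alone.

Measured in a functional assay on A549 cells (Homo sapiens) for antiproliferative activity, read by MTT assay, with a stated time of 48 h; on this read-out higher numbers stand for weaker inhibition and lower numbers for stronger inhibition:
compound 1 `N#CC1=C(N)Oc2c(c3nc4ccccc4nc3c3ccccc23)C12C(=O)N(Cc1cnnn1-c1cc(Cl)ccc1Cl)c1ccccc12` — reported only as a limit, > 50000 nM
compound 2 `CCc1ccccc1-n1nncc1CN1C(=O)C2(C(C#N)=C(N)Oc3c(N)cc4nc5ccccc5nc4c32)c2ccccc21` — 24600 nM

Compound 2 stands as the single numerical result in this assay. The other entry is a limit (the limit of > 50000 nM in this assay, at which 1 of the 2 values shown sits). Compound 3 `N#CC1=C(N)Oc2c(N)cc3nc4ccccc4nc3c2C12C(=O)N(Cc1cnnn1-c1ccc(Cl)cc1Cl)c1ccccc12` differs from compound 2 by 2,4-dichlorophenyl in place of 2-ethylphenyl on an aromatic nitrogen. Going by the values given here, no step between measured compounds is available to set the size of this change, so the expectation is a step of at most modest size, if any, toward weaker inhibition, a 1.2-fold higher number from compound 2 to compound 3 (0.09 log units; within the scatter). Compound 3 is estimated at 30000 nM, with a range from 12000 nM to 75000 nM.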

Compound 3, half-maximal inhibitory concentration: > 50000 nM
Compound 3 ended at the assay's limit (the forecaster's own chance of this, stated with the estimate: 25%); at least 1.6-fold (0.22 log units) between middle value and limit.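

Going by these compounds alone, replacing 2-ethylphenyl with 2,4-dichlorophenyl on the aromatic nitrogen gives the first step at this position in this assay, an at least 2.0-fold higher number from compound 2 to compound 3 (0.30 log units; that floor lies within the scatter). From the compounds shown here alone, compound 3 is reported only as a limit, so the step is a floor and its full size stays unknown. Of the compounds shown, only compound 2 keeps a numerical result, while the others end at the limit: the limit of > 50000 nM in this assay, at which 2 of the 3 values shown sit.

Going by these compounds, whether the step tracks the loss of the ethyl group or the arrival of the two chlorine atoms stays open. Plain phenyl or 2-chlorophenyl on this nitrogen lies outside the compounds shown.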